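This account rests on a few compounds, and the source may have more. Where it says the series, first, only, none or still open, it means among the compounds named here.

The account concerns a toxicity assay on NIH3T3 cells (Mus musculus) for cytotoxicity, read by resazurin assay; on this read-out higher numbers stand for an effect only at larger amounts of compound and lower numbers for an effect already at smaller amounts. Compound 1, with the structure `Nc1cc(-c2ccccc2)ccc1Cn1cncc1CNc1ccc(-c2cncs2)c(-c2ccccc2)c1`, is one of the two compounds with a result. In this assay compound 1 reaches only a limit of the assay, > 1000 nM. Compound 3, `COc1ccc(NCc2cncn2Cc2ccc(-c3ccccc3)cc2N)cc1-c1ccccc1`, differs from compound 1 by methoxy in place of 1,3-thiazol-5-yl on an aromatic carbon. In this assay compound 3 likewise reaches only a limit, > 1000 nM. The step that the two limits leave unreadable from compound 1 to compound 3 is accordingly one that the two limits leave unreadable. Compound 2, `COC(=O)c1ccc(NCc2cncn2Cc2ccc(C(C)(C)C)cc2)cc1-c1ccccc1`, is the starting point of the step followed here. For compound 2 this assay reports "not determined" (no result reported), so no number places it among the others. What surrounds it is the limit of > 1000 nM in this assay, at which 2 of the 3 values shown sit. Compound 4, `COC(=O)c1ccc(NCc2cncn2Cc2ccccc2)cc1-c1ccccc1`, differs from compound 2 by hydrogen in place of tert-butyl on an aromatic carbon. For the measured compounds named here, no measured step bears on this change, and the only step available is unreadable, so no direction can be read for this assay. Given that both measured compounds sit at the limit, compound 4 is expected to show an effect only at the limit or not at all. The estimate for compound 4 is 3000 nM, between 1000 nM and 30000 nM.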

Compound 4, half-maximal effective concentration: > 1000 nM
Compound 4: only a limit was reported (the forecaster's own chance of this, stated with the estimate: 80%); the middle value lies beyond the limit too.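

No new step can be read in this assay from compound 2 to compound 4: compound 2 carries no number. Compound 4 gives only a limit of the assay, > 1000 nM. The compounds shown leave open at which concentration any of them would affect these cells, and whether hydrogen in place of tert-butyl changes the read-out.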